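This account rests on a few compounds, and the source may have more. Where it says the series, first, only, none or still open, it means among the compounds named here.

Working notes on the series. Compound 1 `COc1ccc(N2CCN(C(=S)SCc3ccc(C(=O)Nc4ccccc4N)cc3)CC2)cc1` stands second highest of the three numbers in a functional assay on MGC-803 cells (Homo sapiens) for antiproliferative activity, read by CCK-8 assay, with a stated time of 72 h, tested at 2 uM (on this read-out lower numbers stand for a weaker effect and higher numbers for a stronger effect at the one concentration tested), where compound 1 gives 25.3%. Compound 2 `CC1CCN(C(=S)SCc2ccc(C(=O)Nc3ccccc3N)cc2)CC1` gives 28.1% in this assay, a number within the scatter of compound 1. Compound 3 `Nc1ccccc1NC(=O)c1ccc(CSC(=S)N(Cc2ccccc2)Cc2ccccc2)cc1` gives 11% in this assay, a number beyond the scatter and below compound 1. Going by the values given here, no step between measured compounds that differ in one place is available, so the size of any single change is untested here. Compound 4 `Nc1ccccc1NC(=O)c1ccc(CSC(=S)N2CCN(c3ncccn3)CC2)cc1` differs from compound 1 as follows: pyrimidin-2-yl in place of 4-methoxyphenyl on an amine nitrogen in a ring. The expected step is a number 3.3 percentage points lower from compound 1 to compound 4 (within the scatter), a change not beyond the scatter. Compound 4 is estimated at 22% in this assay, with a range from 10% to 36%.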

Compound 4, a percentage reported as inhibition, at one concentration (the size of the read-out at that concentration, not a potency): 28.4%
Compound 4: middle estimate off by 6.4 percentage points, on the low side; the measured number falls inside the stated range.
By their numbers in this assay, from the lowest: compound 3; then compounds 1, 2 and 4 (each within the scatter of the next).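

Going by these compounds alone, the first step that differs in one place is now available: on an amine nitrogen in a ring, pyrimidin-2-yl in place of 4-methoxyphenyl gives a number 3.1 percentage points higher from compound 1 to compound 4 (within the scatter) in this assay. In this one pair, the aromatic ring on this nitrogen can carry 2 hetero atoms and lose the methoxy group without a change beyond the scatter. Nothing available explains this step or assigns a property to either group. On these data alone, whether pyridin-2-yl, unsubstituted phenyl or an acetyl group on this nitrogen would give a similar number stays open. A read-out at one concentration also leaves the potency of these compounds open.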